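From compound 2 to compound 4: adding a cyano group

The source may report more compounds than this note shows. Statements on the series, on what has been measured and on what is new or still open speak of the compounds shown alone.

In a functional assay on HeLa cells (Homo sapiens) for inhibition, read by sulforhodamine B assay, with a stated time of 74 h (a lower number here means a stronger inhibitor, a higher number a weaker inhibitor), compound 1 `Cc1ccc(S(=O)(=O)N2C(=O)COC23C=CC(=O)C=C3)cc1` gives 180 nM. Compound 2 `O=C1C=CC2(C=C1)OCC(=O)N2S(=O)(=O)c1ccccc1` gives only a limit, > 10000 nM. Compound 3 `O=C1C=CC2(C=C1)OCC(=O)N2S(=O)(=O)c1ccc(Cl)cc1` also gives only a limit, > 10000 nM. Compound 2 thus stands at the limit of > 10000 nM in this assay, at which 2 of the 3 values shown sit, and no number is known for it.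

Compound 4 `N#Cc1cccc(S(=O)(=O)N2C(=O)COC23C=CC(=O)C=C3)c1` differs from compound 2 by one change: cyano in place of hydrogen on an aromatic carbon. In words, this is cyano in place of hydrogen on an aromatic carbon, meta to a large group.

Three measured steps also exchange a group on an aromatic carbon. Hydrogen in place of methyl gives an at least 55-fold higher number from compound 1 to compound 2 (1.74 log units; beyond the scatter), and chloro in place of methyl gives an at least 55-fold higher number from compound 1 to compound 3 (1.74 log units; beyond the scatter). Both are large. The closest parallel, chloro in place of hydrogen, gives a step that the two limits leave unreadable from compound 2 to compound 3, so it offers no size to carry over. Among these compounds, only compound 1 has a measured number, and compound 3 shows that a new group on compound 2 need not produce one.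

Only a modest move toward a lower number is therefore expected, and the expected step is an at least 1.2-fold lower number from compound 2 to compound 4 (0.09 log units; that floor lies within the scatter). For compound 4 the estimate is 8000 nM, with an expected range of 1500 nM to 30000 nM.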

Compound 4, half-maximal inhibitory concentration: 180 nM
The estimate for compound 4 lay 44-fold (1.65 log units) above the measured number; the whole stated range lies above it.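

In this assay, the exchange of hydrogen for cyano on an aromatic carbon, meta to a large group, gives an at least 55-fold lower number from compound 2 to compound 4 (1.74 log units; beyond the scatter), and the step is large. For the compounds shown here, the earlier compounds could not show this: the only step that put a new group on compound 2, the chloro exchange leading to compound 3, cannot be read, so they gave no sign that a new group on this ring could bring a measured number at all. The cyano group does bring one, and the size printed for the step is only a floor, with the true step possibly larger, because compound 2 carries a limit rather than a number: the limit of > 10000 nM in this assay, at which 2 of the 4 values shown sit.

The compounds shown leave open whether the cyano group would give the same result on another carbon of the aromatic ring, so the roles of the group and of its place cannot yet be told apart. They also leave open whether a different group at this same place, such as an amine, a carboxylic acid or a longer chain, would likewise give a number rather than a limit.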